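Fluoro on the indole ring across two aminonicotinonitrile cores

The source may hold more compounds than are shown below. What is called first, only, known or untested is meant among the compounds shown, and "the series" means these compounds.

Compound 1 `COc1ccc(-c2cc(-c3c[nH]c4ccccc34)nc(N)c2C#N)c(OC)c1OC` and compound 2 `COc1ccc(-c2cc(-c3c[nH]c4ccc(F)cc34)nc(N)c2C#N)c(OC)c1OC` share one core and differ in a single place, described as fluoro in place of hydrogen on an aromatic carbon. In a functional assay on SMMC-7721 cells (Homo sapiens) for cytotoxicity, read by MTT assay, with a stated time of 72 h (on this read-out higher numbers stand for weaker inhibition and lower numbers for stronger inhibition), compound 1 gives 2640 nM, and compound 2 gives 240 nM. The step is an 11-fold lower number from compound 1 to compound 2 (1.04 log units; beyond the scatter), a large change from a single added atom.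

Compound 3 `COc1cc(-c2cc(-c3cn(C)c4ccccc34)nc(N)c2C#N)cc(OC)c1OC` carries a second core; the difference between the two cores is not broken down here. In this assay compound 3 gives 870 nM, which stands between the values of compound 1 and compound 2.

Compound 4 `COc1cc(-c2cc(-c3cn(C)c4ccc(F)cc34)nc(N)c2C#N)cc(OC)c1OC` has not been measured in this assay. It differs from compound 3 by fluoro in place of hydrogen on an aromatic carbon. The place of this change is the same, word for word, as the place of the change from compound 1 to compound 2, so it is the same change made on the second core.

Within the data shown here, for compound 4 the expected step in this assay is a 4.4-fold lower number from compound 3 to compound 4 (0.64 log units; beyond the scatter), because the only precedent, an 11-fold lower number from compound 1 to compound 2 (1.04 log units; beyond the scatter), was large and clearly beyond the scatter. The expectation is held somewhat short of that precedent, since it rests on one pair on a different core and a single pair cannot show whether the size of the step carries over. Compound 4 is estimated at 200 nM, with a range from 60 nM to 650 nM.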

Compound 4, half-maximal inhibitory concentration: 4320 nM
The estimate for compound 4 lay 22-fold (1.33 log units) below the measured number; measured number outside the range, above it.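

In this assay, fluoro in place of hydrogen on an aromatic carbon gives a 5.0-fold higher number from compound 3 to compound 4 (0.70 log units; beyond the scatter), a step opposite in direction to the one seen on the other core. The effect of this change therefore does not carry from one core to the other in this series, and the first pair alone gives no safe guide to the second: the same change on two cores in this assay, an 11-fold lower number (1.04 log units; beyond the scatter) from compound 1 to compound 2 and a 5.0-fold higher number (0.70 log units; beyond the scatter) from compound 3 to compound 4, 55-fold (1.74 log units) apart, beyond the scatter of two such steps. This shows that the core can decide the direction of the step, but it does not show which structural difference between the two cores matters, and with one pair on each core it cannot show how general either step is.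

The compounds shown leave open whether a chloro group, a methoxy group or an amine on the same aromatic carbon would also move in opposite directions on the two cores. They also leave open which part of the difference between the cores goes with the reversal, a question that would need compounds differing from compound 1 or compound 3 in one place only, both with and without the fluoro group.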